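Removing one fluoro from a chalcone-bearing lactone amide

The compounds below may be only part of what the source reports. "The series", "measured", "known", "first", "only" and "open" are said of these compounds alone.

Compound 1, with the structure `O=C(COc1ccc(C(=O)/C=C/c2ccc(F)c(F)c2)cc1)N[C@H]1CCOC1=O`, was tested in a functional assay on MCF7 cells (Homo sapiens) for antiproliferative activity, read by MTT assay, with a stated time of 72 h; on this read-out higher numbers stand for weaker inhibition and lower numbers for stronger inhibition; in this assay compound 1 gives > 64000 nM, which is a limit of the assay rather than a number. Two companions share the same lactone amide core but carry an aniline-linked arm instead of the chalcone-bearing ether. Compound 2, `CC(C)c1ccc(NCC(=O)N[C@H]2CCOC2=O)cc1`, gives > 64000 nM in this assay, again a limit. Compound 3, `O=C(CNc1ccc(Br)cc1)N[C@H]1CCOC1=O`, gives > 64000 nM in this assay, also a limit. The one single-point step among these, bromo in place of isopropyl on an aromatic carbon, reads a step that the two limits leave unreadable from compound 2 to compound 3, so it offers no measurable size. In fact every value here sits at the same point, as the evidence shows: the limit of > 64000 nM in this assay, at which 3 of the 3 values shown sit.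

Compound 4, `O=C(COc1ccc(C(=O)/C=C/c2cccc(F)c2)cc1)N[C@H]1CCOC1=O`, differs from compound 1 by hydrogen in place of fluoro on an aromatic carbon. Among the measured compounds shown here, no measured step touches this kind of change, and the only step available was itself unreadable, so there is nothing to set a direction or a size against. Given that compound 1 returns only a limit, compound 4 is expected to return a similar limit, with an expected step that the limit leaves unreadable from compound 1 to compound 4. The estimate for compound 4 in this assay is therefore 100000 nM, spanning 30000 nM to 400000 nM.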

Compound 4, half-maximal inhibitory concentration: > 64000 nM
Compound 4: no number, only a limit (the forecaster's own chance of this, stated with the estimate: 75%); the middle value lies beyond the limit too.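

Compound 1 and compound 4 each return only a limit in this assay, so the step from 3,4-difluorophenyl to 3-fluorophenyl cannot be read: the limit of > 64000 nM in this assay, at which 4 of the 4 values shown sit.

The compounds shown leave open whether this change, or any other among them, alters the activity at all, with no compound yet giving an actual number.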